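This account rests on a few compounds, and the source may have more. Where it says the series, first, only, none or still open, it means among the compounds named here.

Compound 1 `COc1ccc(CCCCOc2ccc(CSc3c(Cl)cccc3Cl)nc2/C=C/C(=O)O)cc1` and compound 2 `O=C(O)/C=C/c1nc(CSc2c(Cl)cccc2Cl)ccc1OCCc1ccc(F)cc1` share a core and differ only in the tail beyond the chain oxygen. In an assay on isolated protein for binding affinity to leukotriene B4 receptor 1 (Homo sapiens) (on this read-out lower numbers stand for stronger inhibition and higher numbers for weaker inhibition), compound 1 gives 1.5 nM, and in this assay compound 2 gives 1.5 nM. The step of no change at the digits printed from compound 1 to compound 2 (within the scatter) shows that exchanging one aryl tail for another at this position left the read-out unchanged. Compound 2 therefore stands level with compound 1 on the numbers at hand.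

Compound 3 `O=C(O)/C=C/c1nc(CSc2c(Cl)cccc2Cl)ccc1OCCCc1ccccc1` carries the change (benzyl in place of 4-fluorophenyl on a saturated chain carbon, two bonds along the chain from an oxygen on an aromatic ring). For the measured compounds named here, the only measured step that bears on this position, no change at the digits printed from compound 1 to compound 2 (within the scatter), was flat, so a second exchange of the aryl tail here is expected to move little. The expected step of a 1.3-fold higher number from compound 2 to compound 3 (0.12 log units; within the scatter) is thus estimated to stay within the scatter. For compound 3 the estimate in this assay is 2 nM, with a range from 0.7 nM to 6 nM.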

Compound 3, inhibition constant: 1.4 nM
Compound 3: the middle estimate sits 1.4-fold (0.15 log units) above what was measured, and the stated range covers the measured number.
By their numbers in this assay, from the lowest: compounds 3, 1 and 2 (each within the scatter of the next).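

In this assay, 3-phenylpropoxy in place of 2-(4-fluorophenyl)ethoxy gives a 1.1-fold lower number from compound 2 to compound 3 (0.03 log units; within the scatter) and so adds a tail without fluorine or methoxy to the two already compared. Phenyl in place of 4-methoxybenzyl gives a 1.1-fold lower number from compound 1 to compound 3 (0.03 log units; within the scatter) and closes the third side of the comparison, so all three tails at this position lie within the scatter of one another. Nothing at hand explains this flat result.

The step from compound 2 to compound 3 alters the fluorine and the chain together, so the compounds shown do not separate the two. Also open, from the compounds shown here alone, is whether the read-out stays level when an amine or a carboxylic acid is placed on the tail, or when a plain alkyl chain without an aromatic ring takes its place.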